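Methyl in place of amino: from compound 3 to compound 4

This account rests on a few compounds, and the source may have more. Where it says the series, first, only, none or still open, it means among the compounds named here.

Compound 1 `Cc1nnc(SCc2coc3ccc(Cl)cc3c2=O)s1`: in a functional assay on SW480 cells (Homo sapiens) for cytotoxicity, read by MTT assay, with a stated time of 72 h (a lower number here means a stronger inhibitor, a higher number a weaker inhibitor), compound 1 gives 3200 nM. Compound 2 `Nc1nc(SCc2coc3ccccc3c2=O)n[nH]1`: in this assay compound 2 gives 21400 nM. Compound 3 `Nc1nnc(SCc2coc3ccccc3c2=O)s1`: in this assay compound 3 reaches only a limit, > 25000 nM.

Compound 3 thus stands at the limit of > 25000 nM in this assay, at which 1 of the 3 values shown sits, not at a number. Compound 4 `Cc1nnc(SCc2coc3ccccc3c2=O)s1` differs from it by methyl in place of amino on an aromatic carbon. Among the compounds with values here, no measured step swaps this group alone. Within the data shown here, the only measured step, an at least 1.1-fold higher number from compound 2 to compound 3 (0.06 log units; that floor lies within the scatter), exchanges one amine-bearing ring for another and lies within the scatter, so it says little here. Compound 1 carries the methyl on the same five-membered ring but differs from compound 3 in a second place as well, and gives a lower number. Compound 4 is expected to give 12000 nM, between 4000 nM and 40000 nM. The expected step is an at least 2.0-fold lower number from compound 3 to compound 4 (0.31 log units; beyond the scatter), toward a lower number.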

Compound 4, half-maximal inhibitory concentration: 1000 nM
For compound 4 the middle estimate is 12-fold (1.08 log units) above the measured one; the measured number lies below the stated range.
By their numbers in this assay, from the lowest: compound 4; then compound 1; then compound 2. At a limit, above all of these: compound 3.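

Methyl in place of amino on this aromatic carbon gives an at least 25-fold lower number from compound 3 to compound 4 (1.39 log units; beyond the scatter), the first measured step at this group alone. Compound 3 stands only at a limit, so that step is a floor: the limit of > 25000 nM in this assay, at which 1 of the 4 values shown sits. The methyl-bearing ring also compares well with the aminotriazole, with a 21-fold lower number from compound 2 to compound 4 (1.33 log units; beyond the scatter), while hydrogen in place of chloro on the core gives a 3.2-fold lower number from compound 1 to compound 4 (0.51 log units; beyond the scatter), so the chloro of compound 1 is not needed for a low number. The compounds shown leave open how an ethyl group, a methoxy group or a carboxylic acid on this carbon would compare with methyl.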